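A few compounds are considered here, and "the series" means these few. Any claim that something is new, unique, unknown or untested is made for them only; others in the source may bear on it.

Compound 1 `COc1ccccc1NC(=S)Nc1ccc2nc(Oc3ccc(F)cc3C(C)O)c(Cc3ccccc3)cc2c1` and compound 2 `COc1ccc(NC(=S)Nc2ccc3nc(Oc4ccc(F)cc4C(C)O)c(Cc4ccccc4)cc3c2)cc1` share one core and differ only in the methoxyphenyl group on an amide-type nitrogen. In a physicochemical assay for lipophilicity (a higher number here means a more lipophilic compound, a lower number a more polar compound), compound 1 gives 7.86, and compound 2 gives 7.86, so compound 2 stands level with compound 1. Compound 3 `COc1cccc(NC(=S)Nc2ccc3nc(Oc4ccc(F)cc4C(C)O)c(Cc4ccccc4)cc3c2)c1` has the same atoms as compound 2, joined differently: 3-methoxyphenyl in place of 4-methoxyphenyl on an amide-type nitrogen. It carries 3-methoxyphenyl in place of 4-methoxyphenyl on the amide-type nitrogen, whose other neighbour is the thiocarbonyl carbon. For the measured compounds named here, only one measured step bears on this, a swap of the same kind, which showed no change at the digits printed from compound 1 to compound 2 (within the scatter). A single pair is thin evidence, but it gives no ground to expect a shift beyond the scatter in this assay. The expected step is no change at the digits printed from compound 2 to compound 3 (within the scatter). The estimated value for compound 3 is 7.86, with a range from 7.6 to 8.1.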

Compound 3, partition coefficient: 7.86
For compound 3 middle estimate and measured number coincide at the digits printed, within the range that was stated.
By their numbers in this assay, from the lowest: compounds 1, 2 and 3 (each within the scatter of the next).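

Swapping 4-methoxyphenyl for 3-methoxyphenyl on the amide-type nitrogen gives no change at the digits printed from compound 2 to compound 3 (within the scatter) and swapping 2-methoxyphenyl for 3-methoxyphenyl gives no change at the digits printed from compound 1 to compound 3 (within the scatter) in this assay for this series. Where a single pair stood before, all three methoxyphenyl arrangements can now be compared, and in this measurement none stands apart from the others. Nothing available here explains this flat result.

All three compounds carry the same methoxyphenyl group, differing only in how it is joined, so they say nothing about a different group at this nitrogen, such as a phenyl ring bearing a carboxylic acid or an amine in place of the methoxy group. As far as these compounds go, whether these three compounds also match in any other kind of measurement remains open as well.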